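A few compounds are considered here, and "the series" means these few. Any claim that something is new, unique, unknown or untested is made for them only; others in the source may bear on it.

Compound 1 `CO[C@H]1C[C@H](Oc2cc(F)c(F)c(-c3cc(F)c(OCCC(C)(C)C(=O)O)c(F)c3)c2)C1` gives in a functional assay on CHO cells for agonist activity at Free fatty acid receptor 1 (Homo sapiens), read by calcium flux (on this read-out lower numbers stand for an effect already at smaller amounts and higher numbers for an effect only at larger amounts of compound), only a limit, > 100000 nM. Compound 2 `CO[C@H]1C[C@H](Oc2cc(F)c(F)c(-c3cc(F)c(OCCCCCC(=O)O)c(F)c3)c2)C1` gives 11000 nM.

For the measured compounds named here, compound 2 therefore holds the only numbered value shown in this assay, while compound 1 rests at the limit of > 100000 nM in this assay, at which 1 of the 2 values shown sits. Going by the values given here, the single measured step, an at least 9.0-fold lower number from compound 1 to compound 2 (0.95 log units; beyond the scatter), is beyond the scatter. Compound 3 `CO[C@H]1C[C@H](Oc2cc(F)c(F)c(-c3cc(F)c(OCCCCCCCC(=O)O)c(F)c3)c2)C1` carries 2-carboxyethyl in place of carboxy on a saturated chain carbon, five bonds along the chain from an oxygen on an aromatic ring. Among the compounds with values here, no measured step covers a lengthening of this chain; the one step known changed branching, not length, so little can be carried over. Compound 3 is expected to give roughly 7000 nM, between 1500 nM and 35000 nM, an estimated step of a 1.6-fold lower number from compound 2 to compound 3 (0.20 log units; within the scatter) that need not exceed the scatter.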

Compound 3, half-maximal effective concentration: 3480 nM
Compound 3: the middle estimate sits 2.0-fold (0.30 log units) above what was measured; the measured number falls inside the stated range.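

In this assay, extending the 3-carboxypropyl to 5-carboxypentyl gives a 3.2-fold lower number from compound 2 to compound 3 (0.50 log units; beyond the scatter), so chain length moves the number at this position, and not only the removal of branching. Against the branched 1-carboxy-1-methylethyl the gain grows to an at least 28-fold lower number from compound 1 to compound 3 (1.45 log units; beyond the scatter). Compound 1 holds a limit, not a number: the limit of > 100000 nM in this assay, at which 1 of the 3 values shown sits.

For the compounds shown here, only two straight chains carry numbers here, so any trend with length rests on that one pair. On these data alone, whether a longer chain lowers the number further, or whether an ether oxygen within the chain would be tolerated, stays open.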